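A few compounds are considered here, and "the series" means these few. Any claim that something is new, unique, unknown or untested is made for them only; others in the source may bear on it.

Measured in a functional assay on U-251 cells (Homo sapiens) for antiproliferative activity, read by MTT assay, with a stated time of 24 h; a higher number here means a weaker inhibitor, a lower number a stronger inhibitor:

- compound 1 `C#CCOc1ccc2c(=O)c(-c3cc(OC)c(OC)cc3OC)coc2c1`: 6450 nM
- compound 2 `COc1cc(OC)c(-c2coc3cc(OCc4ccccc4)ccc3c2=O)cc1OC`: 6750 nM

With only these two numbers in hand, compound 1 has a single neighbour, and the two stand level: the step is a 1.0-fold higher number from compound 1 to compound 2 (0.02 log units; within the scatter). A gap of that size says nothing about which compound is the better inhibitor.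

Next comes compound 3 `COc1cc(OC)c(-c2coc3cc(OCc4ccc(F)cc4)ccc3c2=O)cc1OC`, which has not yet been measured in this assay. Its difference from compound 1 is 4-fluorophenyl in place of ethynyl on a saturated chain carbon bound to an oxygen on an aromatic ring. In words, this is 4-fluorophenyl in place of ethynyl on a saturated chain carbon bound to an oxygen on an aromatic ring.

The one measured step that bears on this change is the step to compound 2 given above, which put phenyl at the same place and moved the number by no more than the scatter. For the measured compounds named here, no measured compound carries 4-fluorophenyl, so that part of the change remains untested, and the range must stay wide. The expected size of the change is small, with no clear direction: a 1.0-fold higher number from compound 1 to compound 3 (0.00 log units; within the scatter). For compound 3 the estimated value is 6500 nM, with an expected range from 3200 nM to 13000 nM.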

Compound 3, half-maximal inhibitory concentration: 3200 nM
The estimate for compound 3 lay 2.0-fold (0.31 log units) above the measured number; low and high end bracket the measured number.
By their numbers in this assay, from the lowest: compounds 3, 1 and 2 (each within the scatter of the next, the first and the last beyond it).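

For the compounds shown here, the clearest comparison so far in this assay is the single swap of fluoro in place of hydrogen on an aromatic carbon (a 2.1-fold lower number from compound 2 to compound 3 (0.32 log units; beyond the scatter)), a modest step that lies beyond the scatter. The earlier pair showed only that an ethynyl and a phenyl at the end of this chain stand level, whereas this pair shows that one small substituent on the phenyl ring can move the number measurably. The full replacement of ethynyl by 4-fluorophenyl, by contrast, stays within the scatter (a 2.0-fold lower number from compound 1 to compound 3 (0.30 log units; within the scatter)), so compound 3 cannot be ranked ahead of compound 1, and nothing available explains why the fluoro group makes a difference.

The compounds shown leave open whether a chloro, a methoxy or a nitrile on the same ring would act as fluoro does, so a single pair cannot yet be called a trend. They also leave open what a chain ending in an amine or a carboxylic acid would do at this place on the shared core.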